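This account rests on a few compounds, and the source may have more. Where it says the series, first, only, none or still open, it means among the compounds named here.

Measured so far:
- compound 1 `CC(C)[C@H](NC(=O)c1cc(Cl)ccc1OCCCCNC(=O)OC(C)(C)C)C(=O)Nc1ccc([N+](=O)[O-])cc1Cl`: > 10000 nM
- compound 2 `CC(C)[C@H](NC(=O)c1cc(Cl)ccc1OCCCCN)C(=O)Nc1ccc([N+](=O)[O-])cc1Cl`: 5590 nM
- compound 3 `CC(C)[C@H](NC(=O)c1cc(Cl)ccc1OCCNC(=O)OC(C)(C)C)C(=O)Nc1ccc(C(F)(F)F)cc1Cl`: > 10000 nM

In a functional assay on MDA-MB-231 cells (Homo sapiens) for inhibition, read by MTT assay, with a stated time of 72 h (a lower number here means a stronger inhibitor, a higher number a weaker inhibitor), compound 1 gives > 10000 nM, which is a limit of the assay, not a number. Compound 2 gives 5590 nM. The change between them is hydrogen in place of tert-butoxycarbonyl on an amine nitrogen, and it made an at least 1.7-fold lower number from compound 1 to compound 2 (0.25 log units; that floor lies within the scatter); that floor rests on (the limit of > 10000 nM in this assay, at which 2 of the 3 values shown sit). Compound 3 gives > 10000 nM, again only a limit. How the core of compound 3 differs from that of compound 1 is not broken down here. Compound 4 `CC(C)[C@H](NC(=O)c1cc(Cl)ccc1OCCN)C(=O)Nc1ccc(C(F)(F)F)cc1Cl` is not yet measured; it differs from compound 3 by hydrogen in place of tert-butoxycarbonyl on an amine nitrogen, the same change made once before, at the same kind of place. Compound 4 is expected to show a step of an at least 1.4-fold lower number from compound 3 to compound 4 (0.15 log units; that floor lies within the scatter) in this assay. That expectation rests on compound 2 reaching 5590 nM after the same change. Compound 4 is therefore estimated at 7000 nM, likely between 2500 nM and 20000 nM.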

Compound 4, half-maximal inhibitory concentration: 5440 nM
Compound 4: the middle estimate sits 1.3-fold (0.11 log units) above what was measured; low and high end bracket the measured number.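

In this assay, hydrogen in place of tert-butoxycarbonyl on the amine nitrogen again gives a measured number rather than a limit, with an at least 1.8-fold lower number from compound 3 to compound 4 (0.26 log units; that floor lies within the scatter). Set beside the earlier case, the change reads alike on two cores only as far as this: the same change on two cores in this assay, an at least 1.7-fold lower number (0.25 log units; that floor lies within the scatter) from compound 1 to compound 2 and an at least 1.8-fold lower number (0.26 log units; that floor lies within the scatter) from compound 3 to compound 4; the limit leaves it open whether they differ. Compound 3 gives > 10000 nM, which is a limit and not a number, so the step shows only a floor and does not establish a real lowering or its true size on either core.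

Going by these compounds, it remains open what an acetyl group or a methyl group on that nitrogen would do. Also open, on these data alone, is what a longer chain would do on a single core, since compound 2 and compound 4 differ in more than one place.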